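Replacing bromo with methylsulfanyl on the shared core

The source may hold more compounds than are shown below. What is called first, only, known or untested is meant among the compounds shown, and "the series" means these compounds.

Compound 1 `CC1(COc2ccc(OC(F)(F)F)cc2)Cn2ccnc2O1`: > 64000 nM (a limit)
Compound 2 `CC1(COc2ccc(OC(F)(F)F)cc2)Cn2c(Br)cnc2O1`: 26000 nM

Among the measured compounds shown here, in an ADME assay on MRC5 cells (Homo sapiens) for cytotoxicity, read by fluorescence, with a stated time of 72 h (on this read-out higher numbers stand for weaker inhibition and lower numbers for stronger inhibition), compound 2 gives 26000 nM, the only exact number so far. Compound 1 gives > 64000 nM, which is a limit of the assay. Compound 3 `CSc1cnc2n1CC(C)(COc1ccc(OC(F)(F)F)cc1)O2` differs from compound 2 in one place: methylsulfanyl in place of bromo on an aromatic carbon. For the measured compounds named here, one measured step touches this aromatic carbon: an at least 2.4-fold lower number from compound 1 to compound 2 (0.39 log units; beyond the scatter), when bromo replaced hydrogen. That single, modest step does not show how methylsulfanyl will compare with bromo, so no change beyond the scatter is expected. The expected step is a 1.2-fold higher number from compound 2 to compound 3 (0.06 log units; within the scatter). Compound 3 is estimated at 30000 nM, with an expected range from 12000 nM to 64000 nM.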

Compound 3, half-maximal inhibitory concentration: 25000 nM
Compound 3: middle estimate off by 1.2-fold (0.08 log units), on the high side, within the range that was stated.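

In this assay, methylsulfanyl and bromo on this aromatic carbon cannot be told apart, with a 1.0-fold lower number from compound 2 to compound 3 (0.02 log units; within the scatter) for the swap. Methylsulfanyl in place of hydrogen gives an at least 2.5-fold lower number from compound 1 to compound 3 (0.40 log units; beyond the scatter) on the same carbon, so two different groups here now part from hydrogen in the same direction. From the compounds shown here alone, whether an amine or a carboxylic acid on this carbon would do the same remains open. The value of compound 1 is a limit, so the full size of these steps from hydrogen also remains open: the limit of > 64000 nM in this assay, at which 1 of the 3 values shown sits.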